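Swapping an Ester for an Aminomethyl Group

The source may report more compounds than this note shows. Statements on the series, on what has been measured and on what is new or still open speak of the compounds shown alone.

Compound 1, `CCCC[S+]([O-])c1sc2nc(-c3nccs3)cc(-c3ccc(CO)cc3)c2c1N`, gives 2.5 nM in an assay for inhibition of 15-hydroxyprostaglandin dehydrogenase [NAD(+)] (Homo sapiens), read by fluorescence, with a stated time of 15 min, in the presence of a further agent that is not named here; a lower number here means a stronger inhibitor, a higher number a weaker inhibitor.
Compound 2, `CCCC[S+]([O-])c1sc2nc(-c3nccs3)cc(-c3ccc(C(=O)OC)cc3)c2c1N`, gives 15.1 nM in this assay.

Within the data shown here, of the two measured compounds, compound 2 has the higher number, and the single measured step that separates them is a 6.0-fold higher number from compound 1 to compound 2 (0.78 log units; beyond the scatter). Compound 3, `CCCC[S+]([O-])c1sc2nc(-c3nccs3)cc(-c3ccc(CN)cc3)c2c1N`, has not yet been measured. It differs from compound 2 by aminomethyl in place of methoxycarbonyl on an aromatic carbon. Among the measured compounds shown here, the only measured step that bears on this change is a 6.0-fold higher number from compound 1 to compound 2 (0.78 log units; beyond the scatter), which shows that exchanging a small group with a hydrogen-bond donor for the ester raised the number. The new group again carries one hydrogen-bond donor, so compound 3 is expected to move back toward compound 1, because compound 1 gives 2.5 nM. The expected step is a 3.8-fold lower number from compound 2 to compound 3 (0.58 log units; beyond the scatter). Compound 3 is therefore estimated at 4 nM, with a range from 1.5 nM to 12 nM.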

Compound 3, half-maximal inhibitory concentration: 11.5 nM
Beside the measured number, compound 3's estimate is 2.9-fold (0.46 log units) below it; the range from low to high includes it.
By their numbers in this assay, from the lowest: compound 1; then compounds 3 and 2 (each within the scatter of the next).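

Putting aminomethyl on this aromatic carbon in place of methoxycarbonyl gives a 1.3-fold lower number from compound 2 to compound 3 (0.12 log units; within the scatter) in this assay and leaves compound 3 not separable from compound 2, so gaining a hydrogen-bond donor here is not enough to reach the number of compound 1. The two groups that carry a donor also do not match, since the swap of a single atom at the end of the chain gives a 4.6-fold higher number from compound 1 to compound 3 (0.66 log units; beyond the scatter) and shows that this position tells hydroxymethyl from aminomethyl. Nothing available here explains this difference.

The compounds shown leave open how a carboxylic acid, a primary amide or a longer chain ending in hydroxy would read at this place. They also leave open whether adding methyl groups to the amine of aminomethyl would shift the number.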